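Piperazine nitrogen substituent in the triazine ether series

This account rests on a few compounds, and the source may have more. Where it says the series, first, only, none or still open, it means among the compounds named here.

Compound 1 `CC1CC(C)CN(c2nc(Nc3ccc(C#N)c(C(F)(F)F)c3)nc(Oc3ccnc4ccccc34)n2)C1` carries a 3,5-dimethylpiperidin-1-yl group on the shared core; in a functional assay on DU-145 cells (Homo sapiens) for cytotoxicity, read by sulforhodamine B assay, with a stated time of 48 h (on this read-out lower numbers stand for stronger inhibition of growth and higher numbers for weaker inhibition of growth), compound 1 gives 68000 nM. Compound 2 `CCN1CCN(c2nc(Nc3ccc(C#N)c(C(F)(F)F)c3)nc(Oc3ccnc4ccccc34)n2)CC1` reports only a limit in this assay, > 100000 nM. Compound 3 `COc1ccc(CN2CCN(c3nc(Nc4ccc(C#N)c(C(F)(F)F)c4)nc(Oc4ccnc5ccccc45)n3)CC2)c(OC)c1OC` likewise reports only a limit in this assay, > 100000 nM. The step of an at least 1.4-fold higher number from compound 1 to compound 2 (0.16 log units; that floor lies within the scatter) is the only readable one, and it lies within the scatter. The step that the two limits leave unreadable from compound 2 to compound 3 cannot be sized, since both values are limits. Compound 2 therefore stands at the limit of > 100000 nM in this assay, at which 2 of the 3 values shown sit, and nothing measured places it apart from compound 3 or from compound 1.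

Compound 4 `N#Cc1ccc(Nc2nc(Oc3ccnc4ccccc34)nc(N3CCN(c4cccc(Cl)c4Cl)CC3)n2)cc1C(F)(F)F` differs from compound 2 by 2,3-dichlorophenyl in place of ethyl on an amine nitrogen in a ring. Among the measured compounds shown here, the step that bears most directly on it is the one from compound 2 to compound 3, which changes the group on the same ring nitrogen and is unreadable; the step from compound 1 to compound 2 replaces the whole ring and is within the scatter. For the measured compounds named here, no measured step gives a direction beyond the scatter, so the expectation rests on the limits. Compound 4 is expected in this assay at 120000 nM, with a range from 40000 nM to 300000 nM. That estimate means an expected step that the limit leaves unreadable from compound 2 to compound 4, most likely reported as a limit again.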

Compound 4, concentration for total growth inhibition: > 100000 nM
Compound 4 ended at the assay's limit (the forecaster's own chance of this, stated with the estimate: 65%); the middle value is on the limit's open side.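

In this assay compound 4 reports only a limit, > 100000 nM, as compound 2 does, so no new step can be read between the two. The compounds shown leave open whether compound 2, compound 3 and compound 4 differ at all in growth inhibition with the group changed on the amine nitrogen in a ring: the limit of > 100000 nM in this assay, at which 3 of the 4 values shown sit.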